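The source may report more compounds than this note shows. Statements on the series, on what has been measured and on what is new or still open speak of the compounds shown alone.

In a functional assay on PC-3 cells (Homo sapiens) for cytotoxicity, read by MTT assay, with a stated time of 48 h (on this read-out higher numbers stand for weaker inhibition and lower numbers for stronger inhibition), three compounds built on a shared core have been measured, and they differ only in one group on the aromatic ring. Compound 1 `CC1(C)CCC[C@]2(C)[C@@H](CC[C@@](C)(O)/C=C/c3ccccc3)[C@](C)(O)CC[C@@H]12`, with hydrogen at that place, gives 121 nM. Compound 2 `CC(C)(C)c1ccc(/C=C/[C@](C)(O)CC[C@@H]2[C@@]3(C)CCCC(C)(C)[C@@H]3CC[C@@]2(C)O)cc1`, with tert-butyl, gives 3800 nM. Compound 3 `CC1(C)CCC[C@]2(C)[C@@H](CC[C@@](C)(O)/C=C/c3ccc(C(=O)O)cc3)[C@](C)(O)CC[C@@H]12`, with carboxy, gives 102 nM, which puts it level with compound 1 within the scatter and far from compound 2.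

The next compound is compound 4 `CC1(C)CCC[C@]2(C)[C@@H](CC[C@@](C)(O)/C=C/c3ccc(Oc4ccccc4)cc3)[C@](C)(O)CC[C@@H]12`, with phenoxy in place of carboxy on an aromatic carbon.

For the measured compounds named here, no phenoxy compound has been measured, so only indirect evidence bears on this change. Carboxy in place of hydrogen gave a 1.2-fold lower number from compound 1 to compound 3 (0.07 log units; within the scatter), so that swap tells little. Tert-butyl in place of hydrogen gave a 31-fold higher number from compound 1 to compound 2 (1.50 log units; beyond the scatter), and carboxy in place of tert-butyl gave a 37-fold lower number from compound 2 to compound 3 (1.57 log units; beyond the scatter). These large steps show that this place can matter. Phenoxy is a large group, like tert-butyl, so a clear move towards a higher number is expected, though probably not the full size of those steps.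

The estimated step is an 8.8-fold higher number from compound 3 to compound 4 (0.95 log units; beyond the scatter). Compound 4 is expected at 900 nM, with an estimated range from 150 nM to 4500 nM.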

Compound 4, half-maximal inhibitory concentration: 268 nM
For compound 4 the middle estimate is 3.4-fold (0.53 log units) above the measured one; the range from low to high includes it.
By their numbers in this assay, from the lowest: compounds 3 and 1 (each within the scatter of the next); then compound 4; then compound 2.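

In this assay, the large loss seen with tert-butyl does not extend to every bulky substituent at this place: a 14-fold lower number from compound 2 to compound 4 (1.15 log units; beyond the scatter) shows that phenoxy, with 7 heavy atoms and an aromatic ring of its own, reads far closer to the other two compounds. Compared with hydrogen the cost is only a 2.2-fold higher number from compound 1 to compound 4 (0.35 log units; beyond the scatter) and compared with carboxy it is a 2.6-fold higher number from compound 3 to compound 4 (0.42 log units; beyond the scatter) on the same scale, both modest steps but beyond the scatter. Among the four groups shown, this position therefore takes an added aromatic ring at a modest cost, and tert-butyl alone brings a large rise.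

Still open, from the compounds shown here alone, is how a small methoxy group or an amine would read here, and whether a phenyl ring joined directly, without the oxygen, would behave like phenoxy. Nothing available accounts for the gap between phenoxy and tert-butyl.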